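The compounds below may be only part of what the source reports. "The series", "measured", "known", "first", "only" and "open" are said of these compounds alone.

Three amides built on one shared core have been measured in a physicochemical assay for lipophilicity, read by HPLC, in phosphate buffer, measured as chromatographic lipophilicity, at pH 7.4; on this read-out higher numbers stand for higher lipophilicity and lower numbers for lower lipophilicity: compound 1 `COc1ccc2nc(C)cc(OCC(=O)Nc3ccccc3)c2c1` gives 4.28, compound 2 `COc1ccc2nc(C)cc(OCC(=O)Nc3c(C)cccc3C)c2c1` gives 4.55, and compound 3 `COc1ccc2nc(C)cc(OCC(=O)Nc3cc(F)cc(F)c3)c2c1` gives 5.13. Compound 3 stands highest of the three, since the step of a number 0.85 log units higher from compound 1 to compound 3 (beyond the scatter) and the step of a number 0.58 log units higher from compound 2 to compound 3 (beyond the scatter) both reach beyond the scatter, whereas a number 0.27 log units higher from compound 1 to compound 2 (within the scatter) does not. Compound 4 `COc1ccc2nc(C)cc(OCC(=O)Nc3nccs3)c2c1` differs from compound 3 in one place: 1,3-thiazol-2-yl in place of 3,5-difluorophenyl on an amide-type nitrogen. The two steps into compound 3 show that swapping the ring on the amide-type nitrogen shifts this assay by modest amounts; with a ring of fewer heavy atoms and two hydrogen-bond acceptors entering, a fall beyond the scatter is expected, a number 1.63 log units lower from compound 3 to compound 4 (beyond the scatter). Compound 4 is therefore estimated at 3.5, between 3 and 4.1.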

Compound 4, distribution coefficient: 3.2
Compound 4: the middle estimate sits 0.30 log units above what was measured, and the stated range covers the measured number.
By their numbers in this assay, from the lowest: compound 4; then compounds 1 and 2 (each within the scatter of the next); then compound 3.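

Until now, changing the ring on the amide-type nitrogen had shifted this assay by modest amounts at most, but 1,3-thiazol-2-yl brings large falls: a number 1.93 log units lower from compound 3 to compound 4 (beyond the scatter), a number 1.35 log units lower from compound 2 to compound 4 (beyond the scatter) and a number 1.08 log units lower from compound 1 to compound 4 (beyond the scatter). Going by these compounds alone, this position can therefore move the read-out much further than the earlier compounds showed, and downward as well as upward. Nothing available explains the size of these falls.

Still open, on these data alone, is whether the ring's hetero atoms or its fewer heavy atoms matter more. A pyridine ring would keep six ring atoms with a ring nitrogen, whereas a thiophene ring would keep five with sulfur alone.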